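This account rests on a few compounds, and the source may have more. Where it says the series, first, only, none or still open, it means among the compounds named here.

Of the compounds shown here, three of this set have been tested for their effect on cells. Compound 1 `COc1cc(C2C(C(=O)Nc3ccc(Cl)cc3)=C(C)NC(C)=C2C(=O)Nc2ccc(Cl)cc2)ccc1O` and compound 2 `CC1=C(C(=O)Nc2ccc(Cl)cc2)C(c2cccc([N+](=O)[O-])c2)C(C(=O)Nc2ccc(Cl)cc2)=C(C)N1` share one core, while compound 3 `COc1ccc(NC(=O)C2=C(C)NC(=O)NC2c2cccc([N+](=O)[O-])c2)cc1` is built on a different core; how the two cores differ is not broken down here. In an ADME assay on Vero cells (Chlorocebus sabaeus) for cytotoxicity, read by sulforhodamine B assay, with a stated time of 3 days (on this read-out lower numbers stand for higher toxicity in this test and higher numbers for lower toxicity in this test), compound 1 gives 250 ug/mL, compound 2 gives 26 ug/mL, and compound 3 gives 64 ug/mL. Compound 2 and compound 1 differ only by 4-hydroxy-3-methoxyphenyl in place of 3-nitrophenyl on a saturated ring carbon, and that change brought a 9.6-fold higher number from compound 2 to compound 1 (0.98 log units; beyond the scatter).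

Compound 4 `COc1ccc(NC(=O)C2=C(C)NC(=O)NC2c2ccc(O)c(OC)c2)cc1` has not yet been tested. It differs from compound 3 by 4-hydroxy-3-methoxyphenyl in place of 3-nitrophenyl on a saturated ring carbon, the same kind of change as from compound 2 to compound 1, but the surroundings are not identical: in compound 2 the saturated ring carbon sits next to two ring atoms that each bear a (4-chlorophenyl)carbamoyl group, whereas in compound 3 it sits next to the ring nitrogen and next to the ring atom that bears a large group.

Because the same kind of change gave a 9.6-fold higher number from compound 2 to compound 1 (0.98 log units; beyond the scatter) on the other core, a step in the same direction is expected here, though on the new core its size is less certain; the expected step is a 3.9-fold higher number from compound 3 to compound 4 (0.59 log units; beyond the scatter). Compound 4 is therefore estimated at 250 ug/mL in this assay, with a plausible range from 100 ug/mL to 600 ug/mL.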

Compound 4, half-maximal cytotoxic concentration: 8 ug/mL
Beside the measured number, compound 4's estimate is 31-fold (1.49 log units) above it; measured number below the stated range.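

In this assay, putting 4-hydroxy-3-methoxyphenyl in place of 3-nitrophenyl gave an 8.0-fold lower number from compound 3 to compound 4 (0.90 log units; beyond the scatter), so on this core the new group goes with higher toxicity in the test. Set beside the same change on the core of compound 1, the effect did not carry over from one core to the other, even in its direction: the same change on two cores in this assay, a 9.6-fold higher number (0.98 log units; beyond the scatter) from compound 2 to compound 1 and an 8.0-fold lower number (0.90 log units; beyond the scatter) from compound 3 to compound 4, 77-fold (1.89 log units) apart, beyond the scatter of two such steps This shows that, among these four compounds, the outcome of the change depends on the core that carries it, but it does not show which feature of the cores is responsible, and one pair on each core gives no general rule for the series.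

Still open, on these data alone, is which part of the 4-hydroxy-3-methoxyphenyl group goes with the opposite outcomes, a question that a phenyl ring carrying only a hydroxy group or only a methoxy group could help to answer on each core. Also open, as far as these compounds go, is how other groups on the saturated ring carbon, such as a 3-aminophenyl group, would behave on the two cores.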